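A few compounds are considered here, and "the series" means these few. Any claim that something is new, unique, unknown or untested is made for them only; others in the source may bear on it.

In an ADME assay on microsomes from liver (Mus musculus) for metabolic stability, with a stated time of 10 min (on this read-out lower numbers stand for a less stable compound and higher numbers for a more stable compound), compound 1 (`CC(=O)N1CCC(C)(C(=O)N2CC[C@](c3ccc(C(OCc4c(F)cccc4F)(C(F)(F)F)C(F)(F)F)cc3)(S(=O)(=O)c3ccc(F)cc3)C2)CC1`) gives 4% and compound 2 (`O=C(N1CCOCC1)N1CC[C@](c2ccc(C(OCc3c(F)cccc3F)(C(F)(F)F)C(F)(F)F)cc2)(S(=O)(=O)c2ccc(F)cc2)C1`) gives 18% while compound 3 (`CC(=O)N1CCN(C(=O)N2CC[C@](c3ccc(C(OCc4c(F)cccc4F)(C(F)(F)F)C(F)(F)F)cc3)(S(=O)(=O)c3ccc(F)cc3)C2)CC1`) gives 59% as the highest of the three numbers. Next in the series is compound 4 (`O=C(O)C1CCN(C(=O)N2CC[C@](c3ccc(C(OCc4c(F)cccc4F)(C(F)(F)F)C(F)(F)F)cc3)(S(=O)(=O)c3ccc(F)cc3)C2)CC1`), which has 4-carboxypiperidin-1-yl in place of 4-acetylpiperazin-1-yl on a carbonyl carbon. All three measured steps change the group at this same place. The step of a number 14 percentage points higher from compound 1 to compound 2 (beyond the scatter) is modest, while the steps of a number 55 percentage points higher from compound 1 to compound 3 (beyond the scatter) and a number 41 percentage points higher from compound 2 to compound 3 (beyond the scatter) are large. Changes here have therefore moved the number substantially, but no measured compound carries the entering group, so the direction of the next step is poorly defined. Only a small upward move is expected, with no clear shift beyond the scatter and wide uncertainty on either side. The expected step is a number 6 percentage points higher from compound 3 to compound 4 (within the scatter) on this estimate. Compound 4 is estimated at 65% with an expected range from 35% to 92% for now.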

Compound 4, percent of the compound remaining: 84%
Compound 4: middle estimate off by 19 percentage points, on the low side; the range from low to high includes it.
By their numbers in this assay, from the lowest: compound 1; then compound 2; then compound 3; then compound 4.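

On the carbonyl carbon, 4-carboxypiperidin-1-yl goes past the previous best group in this assay (a number 25 percentage points higher from compound 3 to compound 4 (beyond the scatter)), and the gap to the other two groups widens (a number 66 percentage points higher from compound 2 to compound 4 (beyond the scatter); a number 80 percentage points higher from compound 1 to compound 4 (beyond the scatter)). A high number at this place therefore does not require the 4-acetylpiperazin-1-yl group or its second ring nitrogen, and a group with one hydrogen-bond donor is tolerated here. No measured evidence bears on what lies behind these rises.

Still open, as far as these compounds go, is whether the carboxylic acid or the piperidine ring carries the gain: a methyl ester or primary amide in place of the carboxylic acid, or a longer chain ending in it, would separate the two. From the compounds shown here alone, whether the gain holds on other read-outs also remains open.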